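Swapping a Benzyl Ether for a Carbamate

This account rests on a few compounds, and the source may have more. Where it says the series, first, only, none or still open, it means among the compounds named here.

As far as these compounds go, this account concerns two measured compounds and one whose result is still open. In an assay on nucleic acid for inhibition of Nucleic Acid, read by fluorescence, tested at 100 uM (on this read-out higher numbers stand for more inhibition at the one concentration tested (going by the name of the read-out) and lower numbers for less inhibition), compound 1 `OC(COCc1ccccc1)Cn1cc(CN2CCN(c3ccccc3)CC2)nn1` gives 37%. Compound 2 `O=C(COc1ccccc1)OC1CCCCC1n1cc(CN2CCN(c3ccccc3)CC2)nn1`, which carries a different linker on the same core, gives 37% in this assay, so the two values sit level within the usual scatter and neither can be set above the other. Compound 3 `CCCCNC(=O)OCC(O)Cn1cc(CN2CCN(c3ccccc3)CC2)nn1` is the next candidate for this assay. It differs from compound 1 in one place: butylcarbamoyl in place of benzyl on an oxygen on a saturated carbon. Within the data shown here, no step between measured compounds is known that isolates this kind of change, so the expectation rests on how little the read-out moved between compound 1 and compound 2 despite their different side chains. The step from compound 1 to compound 3 in this assay is expected to be small, with no direction that rises beyond the scatter, and is estimated at a number 2 percentage points lower from compound 1 to compound 3 (within the scatter). Compound 3 is therefore expected to give 35%, within a range from 20% to 50%.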

Compound 3, a percentage reported as inhibition, at one concentration (the size of the read-out at that concentration, not a potency): 11%
Beside the measured number, compound 3's estimate is 24 percentage points above it, and the stated range ends above it.
By their numbers in this assay, from the lowest: compound 3; then compounds 1 and 2 (each within the scatter of the next).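

In this assay, putting butylcarbamoyl in place of benzyl on an oxygen on a saturated carbon gives a number 26 percentage points lower from compound 1 to compound 3 (beyond the scatter), so this position is not indifferent to what it carries. The level readings of compound 1 and compound 2 could not show this, since those two differ by more than a single change, whereas compound 1 and compound 3 differ in this one place only. The swap keeps the count of heavy atoms but removes the six-membered aromatic ring and brings in an open chain with a hydrogen-bond donor and a hydrogen-bond acceptor, and no independent measurement indicates which of these differences matters for the step.

The compounds shown leave open whether the loss in this assay goes with the departure of the aromatic ring or with the arrival of the carbamate. A butyl group or a benzylcarbamoyl group on the same oxygen would separate those two readings, and how either would behave at this position remains an open question.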